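This account rests on a few compounds, and the source may have more. Where it says the series, first, only, none or still open, it means among the compounds named here.

Working notes on the series. Compound 2 `COc1cc(-c2nn(-c3cccc(NC(=O)Nc4cccc(C(F)(F)F)c4)c3)cc2-c2ccncc2)ccc1Cl` in a functional assay on HT-29 cells (Homo sapiens) for inhibition, read by sulforhodamine B assay, with a stated time of 48 h (on this read-out lower numbers stand for higher toxicity in this test and higher numbers for lower toxicity in this test), gives 4670 nM. Compound 3 `COc1cc(-c2nn(-c3cccc(NC(=O)Nc4ccc(Cl)c(C(F)(F)F)c4)c3)cc2-c2ccncc2)ccc1Cl` gives 21500 nM in this assay. Compound 1 `O=C(Nc1cccc(-n2cc(-c3ccncc3)c(-c3ccc(Cl)c(O)c3)n2)c1)Nc1cccc(C(F)(F)F)c1` gives only a limit of the assay, > 32500 nM, so no number stands for it (the limit of > 32500 nM in this assay, at which 1 of the 3 values shown sits). The two cores differ by chloro in place of hydrogen on an aromatic carbon, and that step reads a 4.6-fold higher number from compound 2 to compound 3 (0.66 log units; beyond the scatter). The change hydrogen in place of methyl on an oxygen on an aromatic ring gave an at least 6.9-fold higher number from compound 2 to compound 1 (0.84 log units; beyond the scatter), a step ending at the limit. Compound 4 `O=C(Nc1cccc(-n2cc(-c3ccncc3)c(-c3ccc(Cl)c(O)c3)n2)c1)Nc1ccc(Cl)c(C(F)(F)F)c1` carries the same change, (hydrogen in place of methyl on an oxygen on an aromatic ring), on the core of compound 3; the place of the change is the same in both pairs. Starting from compound 3 and its value 21500 nM, the expected step is a 4.7-fold higher number from compound 3 to compound 4 (0.67 log units; beyond the scatter), resting on the earlier step of an at least 6.9-fold higher number from compound 2 to compound 1 (0.84 log units; beyond the scatter). Compound 4 is thus expected to give about 100000 nM in this assay, between 32500 nM and 400000 nM, most likely reported only as a limit.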

Compound 4, concentration lethal to 50% of the cells: 22600 nM
For compound 4 the middle estimate is 4.4-fold (0.65 log units) above the measured one, and the stated range ends above it.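

In this assay, methoxy to hydroxy gives a 1.1-fold higher number from compound 3 to compound 4 (0.02 log units; within the scatter), so the change does not carry from the core of compound 2 to the core of compound 3 at the same size: the same change on two cores in this assay, an at least 6.9-fold higher number (0.84 log units; beyond the scatter) from compound 2 to compound 1 and a 1.1-fold higher number (0.02 log units; within the scatter) from compound 3 to compound 4, at least 6.6-fold (0.82 log units) apart, beyond the scatter of two such steps The chloro step likewise depends on the core, with an at least 1.4-fold lower number from compound 1 to compound 4 (0.15 log units; that floor lies within the scatter): the same change on two cores in this assay, a 4.6-fold higher number (0.66 log units; beyond the scatter) from compound 2 to compound 3 and an at least 1.4-fold lower number (0.15 log units; that floor lies within the scatter) from compound 1 to compound 4, at least 6.6-fold (0.82 log units) apart, beyond the scatter of two such steps Compound 1 gives only a limit of the assay, > 32500 nM, so the gap between the steps is a floor, and these two pairs do not show why the steps differ or what the change does on any other core.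

Open, as far as these compounds go, is how an amine or an ethoxy group in place of the hydroxy would read on either core. Also open, from the compounds shown here alone, is whether the hydroxy step on a third core would follow either pair.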